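This account rests on a few compounds, and the source may have more. Where it says the series, first, only, none or still open, it means among the compounds named here.

Of the compounds shown here, three have so far been measured in a functional assay on CCRF-CEM cells (Homo sapiens) for cytotoxicity, read by MTT assay, with a stated time of 72 h; a lower number here means a stronger inhibitor of growth, a higher number a weaker inhibitor of growth. Compound 1 `CC(C)COC(=O)Nc1ccc([Se][Se]c2ccc(NC(=O)OCC(C)C)cc2)cc1` gives 9800 nM, compound 3 `O=C(Nc1ccc([Se][Se]c2ccc(NC(=O)OCc3ccccc3)cc2)cc1)OCc1ccccc1` gives 6400 nM, and compound 2 `CCCOC(=O)Nc1ccc([Se]C#N)cc1` gives 9300 nM. The gaps of compound 2 to compound 1 and to compound 3 both fall within the scatter of the assay, so the three numbers cannot be told apart. Compound 4 `CCCCOC(=O)Nc1ccc([Se]C#N)cc1` has not yet been measured; it differs from compound 2 by methyl in place of hydrogen on a saturated chain carbon, three bonds along the chain from an oxygen next to a carbonyl group. For the measured compounds named here, no step between measured compounds informs this change. With the measured values spread so little, the expected step in this assay is a 1.1-fold lower number from compound 2 to compound 4 (0.04 log units; within the scatter), none beyond the scatter in either direction. Compound 4 is estimated at 8500 nM, within 3000 nM to 25000 nM.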

Compound 4, concentration for 50% growth inhibition: 6500 nM
Compound 4: middle estimate off by 1.3-fold (0.12 log units), on the high side; low and high end bracket the measured number.
By their numbers in this assay, from the lowest: compounds 3, 4, 2 and 1 (each within the scatter of the next).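

Taken as propyl to butyl, the added methyl gives the first step read at this place on the chain: in this assay it is a 1.4-fold lower number from compound 2 to compound 4 (0.16 log units; within the scatter). Lengthening the chain by this one carbon therefore produces no change that can be told from the scatter, so this position is not shown to affect growth inhibition in either direction. Nothing measured here bears on the reason for this result.

From the compounds shown here alone, it remains open whether a longer chain at this place, or a chain ending in an amine or a carboxylic acid, would shift the number beyond the scatter.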